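The source may hold more compounds than are shown below. What is called first, only, known or untested is meant among the compounds shown, and "the series" means these compounds.

Values in a functional assay on RS4-11 cells (Homo sapiens) for inhibition, read by CCK-8 assay, with a stated time of 72 h; a higher number here means a weaker inhibitor, a lower number a stronger inhibitor:
compound 1 `CC1(C)CCC(CN2CCN(c3ccc(C(=O)NS(=O)(=O)c4ccc(NCC5CCOCC5)c([N+](=O)[O-])c4)c(Oc4cnc5[nH]ccc5c4)c3)CC2)=C(c2ccc(C(F)(F)F)cc2)C1`: 6.2 nM
compound 2 `CC1(C)CCC(CN2CCN(c3ccc(C(=O)NS(=O)(=O)c4ccc(NC5CCOC5)c([N+](=O)[O-])c4)c(Oc4cnc5[nH]ccc5c4)c3)CC2)=C(c2ccc(C(F)(F)F)cc2)C1`: 32 nM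
compound 3 `CN1CCC(COc2ccc(S(=O)(=O)NC(=O)c3ccc(N4CCN(CC5=C(c6ccc(C(F)(F)F)cc6)CC(C)(C)CC5)CC4)cc3Oc3cnc4[nH]ccc4c3)cc2[N+](=O)[O-])C1`: 10 nM

Compound 3 sits within the scatter of compound 1 and apart from compound 2. The two steps that place it are a 1.6-fold higher number from compound 1 to compound 3 (0.21 log units; within the scatter) and a 3.2-fold lower number from compound 2 to compound 3 (0.51 log units; beyond the scatter).

Compound 4 `CCN1CCC(COc2ccc(S(=O)(=O)NC(=O)c3ccc(N4CCN(CC5=C(c6ccc(C(F)(F)F)cc6)CC(C)(C)CC5)CC4)cc3Oc3cnc4[nH]ccc4c3)cc2[N+](=O)[O-])CC1` carries 1-ethylpiperidin-4-yl in place of 1-methylpyrrolidin-3-yl, on a saturated chain carbon bound to an oxygen on an aromatic ring: 1-ethylpiperidin-4-yl in place of 1-methylpyrrolidin-3-yl on a saturated chain carbon bound to an oxygen on an aromatic ring.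

For the measured compounds named here, no measured step makes this exact change. The nearest guide is a single pair, in which oxolan-3-yl replaces (oxan-4-yl)methyl: a 5.2-fold higher number from compound 1 to compound 2 (0.71 log units; beyond the scatter). That step also differs in its chain, so it supports only a faint lean towards a lower number for compound 4. The swap from compound 1 to compound 3 stayed within the scatter, a 1.6-fold higher number from compound 1 to compound 3 (0.21 log units; within the scatter), which suggests this end of the molecule tolerates a large change.

No step beyond the scatter is expected, and the estimated step is a 1.3-fold lower number from compound 3 to compound 4 (0.10 log units; within the scatter).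

For compound 4 the expected value is 8 nM, with an estimated range of 3 nM to 25 nM.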

Compound 4, half-maximal inhibitory concentration: 4.9 nM
Compound 4: the middle estimate sits 1.6-fold (0.21 log units) above what was measured; low and high end bracket the measured number.
By their numbers in this assay, from the lowest: compounds 4, 1 and 3 (each within the scatter of the next, the first and the last beyond it); then compound 2.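

In this assay, the change inside the group on this saturated chain carbon bound to an oxygen on an aromatic ring gives a modest step (a 2.0-fold lower number from compound 3 to compound 4 (0.31 log units; beyond the scatter)), so this position responds to the ring and its nitrogen substituent, not only to larger swaps. Against the amino groups, (1-ethylpiperidin-4-yl)methoxy stays within the scatter of ((oxan-4-yl)methyl)amino (a 1.3-fold lower number from compound 1 to compound 4 (0.10 log units; within the scatter)) and is clearly apart from (oxolan-3-yl)amino (a 6.5-fold lower number from compound 2 to compound 4 (0.81 log units; beyond the scatter)). No measurement at hand accounts for these steps.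

Ring size and the group on the ring nitrogen change together from compound 3 to compound 4, so the compounds shown do not separate the two; 1-methylpiperidin-4-yl would do so. Also open, as far as these compounds go, is how (1-ethylpiperidin-4-yl)methylamino would compare with the methoxy-linked group.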